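A few compounds are considered here, and "the series" means these few. Any claim that something is new, unique, unknown or untested is made for them only; others in the source may bear on it.

Measured compounds:
compound 1 `CNc1cc(Oc2ccc(NC(=O)Nc3cccc(C(F)F)c3)cc2)ncn1` gives 100 nM in an assay on isolated protein for inhibition of serine/threonine-protein kinase TNNI3K (Homo sapiens); on this read-out higher numbers stand for weaker inhibition and lower numbers for stronger inhibition
compound 2 `CNc1cc(Oc2cc(C)c(NC(=O)Nc3cccc(C(F)(F)F)c3)cc2C)ncn1` gives 32 nM in this assay

Of the two numbers seen so far, compound 1 stands at the higher one; compound 2 sits at a lower value, and that gap lies beyond the usual scatter of this kind of measurement. Compound 2 differs from compound 1 in more than one place, so those two values are reported side by side without a single change being read from them.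

Compound 3 `CCc1cccc(NC(=O)Nc2ccc(Oc3cc(NC)ncn3)cc2)c1` has not yet been measured. It differs from compound 1 by one change, (ethyl in place of difluoromethyl on an aromatic carbon). Among the compounds with values here, no single-change pair among the measured compounds speaks to this swap, so there is no measured step to lean on. The account expects a step from compound 1 to compound 3 of a 1.3-fold higher number from compound 1 to compound 3 (0.11 log units; within the scatter), which is no step beyond the scatter, with a modest lean toward a higher number. For compound 3 the estimate in this assay is 130 nM, with a range from 50 nM to 350 nM.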

Compound 3, half-maximal inhibitory concentration: 200 nM
The estimate for compound 3 lay 1.5-fold (0.19 log units) below the measured number; the measured number falls inside the stated range.
By their numbers in this assay, from the lowest: compound 2; then compounds 1 and 3 (each within the scatter of the next).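

In this assay, within the data shown here, the pair gives the first reading of a single change at this position: ethyl in place of difluoromethyl, on an aromatic carbon meta to a large group, amounts to a 2.0-fold higher number from compound 1 to compound 3 (0.30 log units; within the scatter). This assay therefore does not separate these two groups, and for this one pair the two fluorine atoms of difluoromethyl are not needed to keep the value within the scatter. Nothing available explains this outcome.

From the compounds shown here alone, whether a longer chain such as propyl, an amine or a carboxylic acid at this position would give a step beyond the scatter remains open. Compound 2 differs from compound 1 and compound 3 in more than one place, so its steps to them cannot be read, and the separate contributions of its differences stay unresolved.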